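Sulfonyl substituent series: sulfone against sulfonamide

The source may hold more compounds than are shown below. What is called first, only, known or untested is meant among the compounds shown, and "the series" means these compounds.

Measured compounds:
compound 1 `CC(C)c1noc(N2CCN(C(=O)[C@@H]3CCCN(S(=O)(=O)c4ccc(S(=O)(=O)C5CCC5)cc4)C3)CC2)n1` gives 70 nM in a functional assay on MIA PaCa-2 cells (Homo sapiens) for inhibition, read by MTT assay, with a stated time of 7 days; on this read-out higher numbers stand for weaker inhibition and lower numbers for stronger inhibition
compound 2 `CC(C)c1noc(N2CCN(C(=O)[C@@H]3CCCN(S(=O)(=O)c4ccc(S(=O)(=O)NC(C)(C)C)cc4)C3)CC2)n1` gives 300 nM in this assay
compound 3 `CC(C)c1noc(N2CCN(C(=O)[C@@H]3CCCN(S(=O)(=O)c4ccc(S(=O)(=O)C(C)C)cc4)C3)CC2)n1` gives 70 nM in this assay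

Compound 3 sits level with compound 1 at the digits reported, the two together at the low end of the three numbers; the only separation within the set is a 4.3-fold lower number from compound 2 to compound 3 (0.63 log units; beyond the scatter), a modest gap that exceeds the scatter. Compound 1 and compound 3 cannot be ordered against each other.

The next step is to compound 4 `CC(C)NS(=O)(=O)c1ccc(S(=O)(=O)N2CCC[C@@H](C(=O)N3CCN(c4nc(C(C)C)no4)CC3)C2)cc1`: isopropylamino in place of isopropyl on a sulfonyl sulfur. Among the compounds with values here, two measured steps bear on it. Both a 4.3-fold higher number from compound 1 to compound 2 (0.63 log units; beyond the scatter) and a 4.3-fold lower number from compound 2 to compound 3 (0.63 log units; beyond the scatter) place a sulfamoyl alkylamino group against a sulfonyl alkyl group on the same sulfur, and each time the amino-linked group carries the higher number by the same modest margin. Within the data shown here, no measured pair compares isopropylamino directly; the tert-butylamino of compound 2 is the nearest comparator. On that basis a step of similar size in the weaker direction is expected, a 4.3-fold higher number from compound 3 to compound 4 (0.63 log units; beyond the scatter). Compound 4 is therefore estimated at 300 nM in this assay, with a range of 100 nM to 900 nM.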

Compound 4, half-maximal inhibitory concentration: 2600 nM
Estimate against measurement, compound 4: 8.7-fold (0.94 log units) below; the whole stated range lies below it.
By their numbers in this assay, from the lowest: compounds 1 and 3 (each within the scatter of the next); then compound 2; then compound 4.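

In this assay, isopropylamino in place of isopropyl on a sulfonyl sulfur gives a 37-fold higher number from compound 3 to compound 4 (1.57 log units; beyond the scatter) and a large step again with a 37-fold higher number from compound 1 to compound 4 (1.57 log units; beyond the scatter) when the group replaced is cyclobutyl, so an amino-linked group at this position can cost much more than a 4.3-fold higher number from compound 1 to compound 2 (0.63 log units; beyond the scatter) had indicated. The two amino-linked groups also differ from each other, with an 8.7-fold higher number from compound 2 to compound 4 (0.94 log units; beyond the scatter) for hydrogen in place of methyl on a saturated chain carbon bound to two saturated chain carbons and a sulfonamide nitrogen; the level at this position therefore follows the group carried on the nitrogen and not the nitrogen link alone. Nothing measured in the material at hand accounts for these steps.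

Still open, on these data alone, is whether the hydrogen on the sulfonamide nitrogen or the carbon group on that nitrogen sets the level, a question on which dimethylamino or cyclobutylamino on the same sulfur would bear. Also open, as far as these compounds go, is how a methyl or a longer chain such as n-butyl on the sulfonyl sulfur would stand against isopropyl and cyclobutyl.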